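The source may report more compounds than this note shows. Statements on the series, on what has been measured and on what is new or still open speak of the compounds shown alone.

Measured in a functional assay on the whole organism for antagonist activity, with Mus musculus as the target; on this read-out lower numbers stand for an effect already at smaller amounts and higher numbers for an effect only at larger amounts of compound:
- compound 1 `CC(=O)N(C)CC#CCn1cncc1C`: 6.6 mg/kg
- compound 2 `CCOC(=O)N(C)CC#CCn1cncc1C`: 66 mg/kg
- compound 3 `CCOC(=O)N(C)C(C)C#CCn1cncc1C`: 9.7 mg/kg

Of these three, compound 2 carries the highest number, at 66 mg/kg. Compound 4 `Cc1cncn1CC#CCN(C)C(=O)N(C)C` has not yet been measured in this assay. It differs from compound 2 at one place: dimethylamino in place of ethoxy on a carbonyl carbon. Dimethylamino stands in place of ethoxy on a carbonyl carbon, so ethoxycarbonyl becomes dimethylcarbamoyl.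

The most relevant measured step changes the same place, with ethoxy in place of methyl on a carbonyl carbon: a 10-fold higher number from compound 1 to compound 2 (1.00 log units; beyond the scatter). The other step, a 6.8-fold lower number from compound 2 to compound 3 (0.83 log units; beyond the scatter), adds a methyl at a different place, so it shows only how large a single change can be in this small set. Among the measured compounds shown here, no measured compound carries dimethylamino, which leaves the size of the new step uncertain.

A move away from ethoxy is expected to lower the number, though perhaps not as far as in compound 1. The expected change is a 3.0-fold lower number from compound 2 to compound 4 (0.48 log units; beyond the scatter). For compound 4 the estimated value is 22 mg/kg, with an expected range from 6 mg/kg to 80 mg/kg.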

Compound 4, dose for half-maximal effect: 9.7 mg/kg
For compound 4 the middle estimate is 2.3-fold (0.36 log units) above the measured one; the range from low to high includes it.
By their numbers in this assay, from the lowest: compounds 1, 3 and 4 (each within the scatter of the next); then compound 2.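

Dimethylamino in place of ethoxy on this carbonyl carbon gives a 6.8-fold lower number from compound 2 to compound 4 (0.83 log units; beyond the scatter) even though both groups hold 3 heavy atoms, so the heavy-atom count alone does not set the number here. Compared with the methyl group of compound 1, dimethylamino gives a 1.5-fold higher number from compound 1 to compound 4 (0.17 log units; within the scatter) and so leaves the two groups unseparated, with only the ethoxy of compound 2 standing apart among the three groups tried at this place. Nothing available explains why ethoxy differs from the other two groups.

On these data alone, it remains open whether a methoxy, an amino or a pyrrolidinyl group at this carbonyl carbon would match dimethylamino or ethoxy. As far as these compounds go, it is also open whether the extra methyl on the chain carbon of compound 3 would change the number when added to compound 4.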